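Methyl step from the unmeasured compound 2

The source may report more compounds than this note shows. Statements on the series, on what has been measured and on what is new or still open speak of the compounds shown alone.

Measured so far in a functional assay on MCF7 cells (Homo sapiens) for cytotoxicity, read by MTT assay, with a stated time of 48 h (on this read-out lower numbers stand for stronger inhibition and higher numbers for weaker inhibition), as follows:
compound 1 (`CCn1c(/C=C2/C(=O)Nc3ccc(F)cc32)nc2ccccc21`) gives > 50000 nM
compound 2 (`CCn1c(/C=C2/C(=O)Nc3ccccc32)nc2ccccc21`) gives "not determined" (no result reported)
compound 3 (`CC(C)n1c(/C=C2/C(=O)Nc3ccccc32)nc2ccccc21`) gives 39500 nM

As far as these compounds go, compound 2 has no number of its own: its entry in this assay reads "not determined" (no result reported), so its place stays open. Compound 1 stands at a limit of the assay, and that limit is not a number: the limit of > 50000 nM in this assay, at which 1 of the 3 values shown sits. Among the measured compounds shown here, the only true number in the set belongs to compound 3 at 39500 nM, a high figure that marks weak inhibition.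

The next compound to be tested is compound 4 (`CCn1c(/C=C2/C(=O)Nc3ccc(C)cc32)nc2ccccc21`). The change is methyl in place of hydrogen on an aromatic carbon. For the measured compounds named here, no pair of measured compounds differs in one place, so the series gives no measured size for such a step. A step no larger than the usual scatter is expected in this assay, with no direction favoured. The expectation therefore rests on compound 3 at 39500 nM, and a reading in that same high region seems likely. A result reported only as a limit, as for compound 1, is also possible.

For compound 4 the estimated value is 40000 nM, with an expected range from 18000 nM to 60000 nM.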

Compound 4, half-maximal inhibitory concentration: > 50000 nM
Compound 4: only a limit was reported (the forecaster's own chance of this, stated with the estimate: 40%); middle value at least 1.2-fold (0.09 log units) away from the limit.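

No step can be read from compound 1 to compound 4, since both results are limits and not numbers: the limit of > 50000 nM in this assay, at which 2 of the 4 values shown sit.

The compounds shown leave open what size the step of methyl in place of fluoro on an aromatic carbon has, and whether any group at that place on the shared core gives a true number.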